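This account rests on a few compounds, and the source may have more. Where it says the series, first, only, none or still open, it means among the compounds named here.

Compound 1 `CCOC(=O)CNc1nc(Nc2ccccc2)ncc1[N+](=O)[O-]` — in a functional assay on HepG2 cells (Homo sapiens) for antiproliferative activity, read by MTT assay, with a stated time of 48 h (a lower number here means a stronger inhibitor, a higher number a weaker inhibitor), compound 1 gives only a limit of the assay, > 100000 nM.
Compound 2 `CCOC(=O)CNc1nc(Nc2ccc(Cl)cc2)ncc1[N+](=O)[O-]` — in this assay compound 2 likewise gives only a limit, > 100000 nM.
Compound 3 `CCOC(=O)CNc1nc(NCc2ccccc2)ncc1[N+](=O)[O-]` — in this assay compound 3 also gives only a limit, > 100000 nM.

Compound 3 therefore stands at a limit rather than at a measured number, and the same holds for the two other measured compounds. All three values sit at the same limit (the limit of > 100000 nM in this assay, at which 3 of the 3 values shown sit). The steps among them cannot be read: a step that the two limits leave unreadable from compound 1 to compound 2, a step that the two limits leave unreadable from compound 1 to compound 3 and a step that the two limits leave unreadable from compound 2 to compound 3 all remain unreadable because both ends are limits.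

The new compound 4 `CCOC(=O)CNc1nc(Nc2ccc(OC)cc2)ncc1[N+](=O)[O-]` differs from compound 3 by one change: 4-methoxyphenyl in place of benzyl on a nitrogen on an aromatic ring. None of the three steps gives a readable size, so no direction can be taken from them. All that the measured data show is that the shared core of compounds 1, 2 and 3 has not reached a measurable number in this assay with any of the three groups tried.

Compound 4 is therefore expected to give a step that the limit leaves unreadable from compound 3 to compound 4, that is, no readable change. The estimate for compound 4 is 150000 nM, with a range from 40000 nM to 600000 nM, and most likely again only a limit.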

Compound 4, half-maximal inhibitory concentration: > 100000 nM
Compound 4 ended at the assay's limit (the forecaster's own chance of this, stated with the estimate: 85%); the middle value is on the limit's open side.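

No new step can be read between compound 4 and compound 1, compound 2 or compound 3, because none of these values in this assay is a number, only a limit: the limit of > 100000 nM in this assay, at which 4 of the 4 values shown sit.
The compounds shown leave open whether these four differ from one another at all, and which change to the shared core, if any, would give a measurable number.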